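A few compounds are considered here, and "the series" means these few. Any claim that something is new, unique, unknown or untested is made for them only; others in the source may bear on it.

Measured so far:
Compound 1, `CC1CCCCN1C(=S)SCc1ccc(C(=O)Nc2ccccc2N)cc1`, gives 76.3% in a functional assay on HeLa cells (Homo sapiens) for antiproliferative activity, read by CCK-8 assay, with a stated time of 72 h, tested at 8 uM; a higher number here means a stronger effect of the compound at the concentration tested, a lower number a weaker effect.
Compound 2, `CN(Cc1ccncc1)C(=S)SCc1ccc(C(=O)Nc2ccccc2N)cc1`, gives 72.7% in this assay.
Compound 3, `Nc1ccccc1NC(=O)c1ccc(CSC(=S)N2CCc3cc(Cl)ccc32)cc1`, gives 65.1% in this assay.

All three share the same core, differing only in the group attached to the thiocarbonyl carbon. Compound 3 has the lowest of the three numbers: the step of a number 11.2 percentage points lower from compound 1 to compound 3 (beyond the scatter) lies beyond the scatter, while the step of a number 7.6 percentage points lower from compound 2 to compound 3 (within the scatter) and the step of a number 3.6 percentage points lower from compound 1 to compound 2 (within the scatter) do not. Compound 4, `Nc1ccccc1NC(=O)c1ccc(CSC(=S)N2CCc3ccccc32)cc1`, differs from compound 3 in one place: hydrogen in place of chloro on an aromatic carbon. Among the measured compounds shown here, none of the measured steps touches this position; all of them exchange the whole group on the thiocarbonyl carbon, so none of them bears directly on the loss of a chloro from the 5-chloro-2,3-dihydro-1H-indol-1-yl group. For the measured compounds named here, with no comparable step to lean on, and the change small, a step no larger than the scatter is expected in this assay, in either direction. The expected step is a number 1.1 percentage points lower from compound 3 to compound 4 (within the scatter). Compound 4 is therefore estimated at 64%, with a range from 50% to 78%.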

Compound 4, a percentage reported as inhibition, at one concentration (the size of the read-out at that concentration, not a potency): 67%
Compound 4: the middle estimate sits 3 percentage points below what was measured; low and high end bracket the measured number.
By their numbers in this assay, from the lowest: compounds 3, 4, 2 and 1 (each within the scatter of the next, the first and the last beyond it).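

On an aromatic carbon of the 2,3-dihydro-1H-indol-1-yl group, exchanging chloro for hydrogen gives a number 1.9 percentage points higher from compound 3 to compound 4 (within the scatter) in this assay, so this assay cannot tell the two compounds apart and the chloro is not needed to keep the read-out at this level. Set against the other groups on the thiocarbonyl carbon, the group without chloro gives a number 5.7 percentage points lower from compound 2 to compound 4 (within the scatter) and a number 9.3 percentage points lower from compound 1 to compound 4 (within the scatter), so the one step beyond the scatter among the earlier compounds has no counterpart once the chloro is gone. Nothing measured here offers a reason for this result.

Only chloro and hydrogen are shown at this position, so it remains open how a methoxy, an amine or a carboxylic acid on the same carbon would read. A single concentration in one cell line also leaves open whether compounds this close would differ in potency.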